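The source may hold more compounds than are shown below. What is called first, only, known or untested is meant among the compounds shown, and "the series" means these compounds.

Working notes on the series. Compound 3, `Clc1ccc(-c2nnc(-c3nsc4ccccc34)o2)cc1`, is the reference point for this step. In a functional assay on the whole organism for inhibition, with Rattus norvegicus as the target, with a stated time of 3.5 h, at a dose of 100 mg/kg by the oral route (a higher number here means more inhibition at the dose given (going by the name of the read-out), a lower number less inhibition), compound 3 gives 24%, which stands second highest of the three numbers in hand. Its neighbours are compound 1, `Cc1nnc(-c2nsc3ccccc23)o1`, which in this assay gives 21%, and compound 2, `c1ccc(-c2nnc(-c3nsc4ccccc34)o2)cc1`, which in this assay gives 32%. Among the measured steps, phenyl in place of methyl on an aromatic carbon gave a number 11 percentage points higher from compound 1 to compound 2 (beyond the scatter), 4-chlorophenyl in place of methyl on an aromatic carbon gave a number 3 percentage points higher from compound 1 to compound 3 (within the scatter), and chloro in place of hydrogen on an aromatic carbon gave a number 8 percentage points lower from compound 2 to compound 3 (within the scatter). Compound 3 therefore sits among the others without a step beyond the scatter on either side.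

Compound 4, `COc1ccc(-c2nnc(-c3nsc4ccccc34)o2)cc1`, differs from compound 3 by methoxy in place of chloro on an aromatic carbon. Within the data shown here, the one measured step that touches this ring position is a number 8 percentage points lower from compound 2 to compound 3 (within the scatter), within the scatter, and there is no measured methoxy analogue to compare with. On that basis no step beyond the scatter is expected in this assay, in either direction. The step from compound 3 to compound 4 is expected to be a number 3 percentage points higher from compound 3 to compound 4 (within the scatter). Compound 4 is estimated to give 27% in this assay, with a range from 14% to 40%.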

Compound 4, a percentage reported as inhibition, in the whole organism at one dose (the size of the read-out at that dose, not a potency): 29%
Compound 4: middle estimate off by 2 percentage points, on the low side, within the range that was stated.
By their numbers in this assay, from the lowest: compounds 1, 3, 4 and 2 (each within the scatter of the next, the first and the last beyond it).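

In this assay, methoxy in place of chloro on this aromatic carbon, para to a large group, gives a number 5 percentage points higher from compound 3 to compound 4 (within the scatter), and methoxy in place of hydrogen gives a number 3 percentage points lower from compound 2 to compound 4 (within the scatter). Among these compounds, the position has now carried hydrogen, chloro and methoxy, and no pair among compounds 2, 3 and 4 is separated beyond the scatter, so exchanging the single chlorine atom for the two heavy atoms of methoxy, with its one hydrogen-bond acceptor, produces no resolvable step at this one oral dose. Nothing available explains these small steps.

On these data alone, whether an amine, a carboxylic acid or a longer chain such as butoxy at this same position would produce a step beyond the scatter remains open, as does whether methoxy would behave the same way on another carbon of this ring. With a single dose as the only read-out, the compounds shown also leave open whether compounds 2, 3 and 4 would separate at other doses.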